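This account rests on a few compounds, and the source may have more. Where it says the series, first, only, none or still open, it means among the compounds named here.

Compound 1 `O=C(/C=C/c1ccco1)c1ccc(NC(=O)c2cccs2)cc1` and compound 2 `O=C(/C=C/c1ccco1)c1ccc(NC(=O)c2ccccc2)cc1` share a core and differ only in that compound 2 carries phenyl in place of thiophen-2-yl on a carbonyl carbon. In a functional assay on HCT-116 cells (Homo sapiens) for cytotoxicity, read by resazurin assay, with a stated time of 48 h (a higher number here means that more compound is needed for the effect, a lower number that less compound is needed), compound 1 gives 45000 nM, and compound 2 gives 59000 nM, a step of a 1.3-fold higher number from compound 1 to compound 2 (0.12 log units; within the scatter). Compound 3 `O=C(/C=C/c1cccc([N+](=O)[O-])c1)c1ccc(NC(=O)c2cccs2)cc1` has a different core, carrying (3-nitrophenyl in place of furan-2-yl on a double-bonded chain carbon bound to a double-bonded chain carbon); in this assay compound 3 gives 2500 nM, a step of an 18-fold lower number from compound 1 to compound 3 (1.26 log units; beyond the scatter). Compound 4 `O=C(/C=C/c1cccc([N+](=O)[O-])c1)c1ccc(NC(=O)c2ccccc2)cc1` is made from compound 3 by the same change seen before: phenyl in place of thiophen-2-yl on a carbonyl carbon. Compound 4 is expected to lie close to compound 3, with an estimated step of a 1.3-fold higher number from compound 3 to compound 4 (0.11 log units; within the scatter), because the earlier step of a 1.3-fold higher number from compound 1 to compound 2 (0.12 log units; within the scatter) was small and within the scatter. Compound 4 is therefore estimated at 3200 nM, between 1300 nM and 8000 nM.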

Compound 4, half-maximal effective concentration: 25000 nM
Beside the measured number, compound 4's estimate is 7.8-fold (0.89 log units) below it, outside the stated range (above it).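

In this assay, with 3-nitrophenyl in place of furan-2-yl, the swap of thiophen-2-yl for phenyl gives a 10-fold higher number from compound 3 to compound 4 (1.00 log units; beyond the scatter), which does not repeat the earlier small step: the same change on two cores in this assay, a 1.3-fold higher number (0.12 log units; within the scatter) from compound 1 to compound 2 and a 10-fold higher number (1.00 log units; beyond the scatter) from compound 3 to compound 4, 7.6-fold (0.88 log units) apart, beyond the scatter of two such steps

Read the other way, the 3-nitrophenyl change still gives a 2.4-fold lower number from compound 2 to compound 4 (0.37 log units; beyond the scatter) with benzamido present, but its size depends on the acyl group: the same change on two cores in this assay, an 18-fold lower number (1.26 log units; beyond the scatter) from compound 1 to compound 3 and a 2.4-fold lower number (0.37 log units; beyond the scatter) from compound 2 to compound 4, 7.6-fold (0.88 log units) apart, beyond the scatter of two such steps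

These four compounds thus show that the two changes do not act independently of each other, but they do not show why, or whether this holds beyond this one pair of changes.

As far as these compounds go, it remains open whether the same dependence appears with a nitrile or an amine in place of the nitro group. From the compounds shown here alone, it is equally open for a pyridine ring in place of the thiophen-2-yl.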